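Enantiomer of the atrium agonist series: the undrawn centre

The source may hold more compounds than are shown below. What is called first, only, known or untested is meant among the compounds shown, and "the series" means these compounds.

Measured compounds:
compound 1 `Cc1nc(N)sc1CCCNC(=N)NC(=O)C[C@@H](C)c1ccccc1` 102 nM
compound 2 `Cc1nc(N)sc1CCCNC(=N)NC(=O)C[C@H](C)C1CCCCC1` 91.2 nM
compound 3 `Cc1nc(N)sc1CCCNC(=N)NC(=O)CC(C)c1ccccc1` 49 nM

In a functional assay on cardiac atrium for agonist activity at histamine H2 receptor (Cavia porcellus) (a lower number here means that less compound is needed, a higher number that more compound is needed for the effect), compound 3 gives 49 nM. Against compound 1 it sits lower by a 2.1-fold lower number from compound 1 to compound 3 (0.32 log units; beyond the scatter), a step that rests on (the fact that one of compounds 1 and 3 is drawn with a defined configuration and the other without, at the place where they differ). Against compound 2 the gap is a 1.9-fold lower number from compound 2 to compound 3 (0.27 log units; within the scatter), so those two numbers cannot be ordered. Replacing the ring, a 1.1-fold lower number from compound 1 to compound 2 (0.05 log units; within the scatter), changes little.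

Compound 4 `Cc1nc(N)sc1CCCNC(=N)NC(=O)C[C@H](C)c1ccccc1` differs from compound 3 only in that (the two compounds have the same atoms and bonds; at least one stereo element is drawn with a configuration in one of them and without one in the other: 1 of 2 stereo elements differ; a stereocentre at a saturated chain carbon is drawn without a configuration in compound 3 and S in compound 4). Among the measured compounds shown here, the steps that bear on this are the one from compound 1 to compound 3, where drawing the centre without a configuration lowered the number, and the small change from compound 1 to compound 2. Since compound 3 already lies below compound 1 by a 2.1-fold lower number from compound 1 to compound 3 (0.32 log units; beyond the scatter), the remaining configuration is expected to lie at or below compound 3 in this assay. The expected step is a 1.4-fold lower number from compound 3 to compound 4 (0.15 log units; within the scatter), modest and downward. For compound 4 the estimate is 35 nM, in the range 15 nM to 90 nM.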

Compound 4, half-maximal effective concentration: 39.8 nM
Estimate against measurement, compound 4: 1.1-fold (0.06 log units) below; low and high end bracket the measured number.
By their numbers in this assay, from the lowest: compounds 4, 3, 2 and 1 (each within the scatter of the next, the first and the last beyond it).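

In this assay the two drawn configurations at the saturated chain carbon can now be told apart: going from R to S gives a 2.6-fold lower number from compound 1 to compound 4 (0.41 log units; beyond the scatter). The undrawn compound 3 cannot be separated from the S form, with a 1.2-fold lower number from compound 3 to compound 4 (0.09 log units; within the scatter), so the lower number of compound 3 against compound 1 now has a drawn counterpart in compound 4. The ring change also becomes readable, since a 2.3-fold lower number from compound 2 to compound 4 (0.36 log units; beyond the scatter) lies beyond the scatter, unlike a 1.1-fold lower number from compound 1 to compound 2 (0.05 log units; within the scatter), so the effect of replacing cyclohexyl with phenyl depends on which phenyl compound is the partner.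

The compounds shown leave open how the opposite configuration of the cyclohexyl compound reads in this assay. Also open, as far as these compounds go, is what an ethyl in place of the methyl on this stereocentre would do to either configuration.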